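Dipropylamino for azetidinyl on the shared quinone-like core

The compounds below may be only part of what the source reports. "The series", "measured", "known", "first", "only" and "open" are said of these compounds alone.

Compound 2 `O=C1C=C(N2CCC2)C(=O)c2c1nc1n2[C@H]2OC[C@@H](O)[C@H]2OC1` carries azetidin-1-yl on the core. In a functional assay on MGC-803 cells (Homo sapiens) for inhibition, read by sulforhodamine B assay (on this read-out lower numbers stand for stronger inhibition and higher numbers for weaker inhibition), compound 2 reports only a limit, > 16000 nM, not a number. Compound 1 `O=C1C(Nc2ccccc2)=CC(=O)c2c1nc1n2[C@H]2OC[C@@H](O)[C@H]2OC1`, with phenylamino at the same place, gives 1830 nM in this assay. Compound 3 `O=C1C(NC2CCCC2)=CC(=O)c2c1nc1n2[C@H]2OC[C@@H](O)[C@H]2OC1` in this assay likewise stops at a limit, > 16000 nM. Going by the values given here, the one measured step, an at least 8.7-fold higher number from compound 1 to compound 3 (0.94 log units; beyond the scatter), is the only guide, and it only brackets the loss; the limit of > 16000 nM in this assay, at which 2 of the 3 values shown sit, marks where two of the three values sit.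

Compound 4 `CCCN(CCC)C1=CC(=O)c2nc3n(c2C1=O)[C@H]1OC[C@@H](O)[C@H]1OC3` differs from compound 2 by dipropylamino in place of azetidin-1-yl on a double-bonded ring carbon. Both the group that leaves and the one that enters are amines without the phenyl of compound 1, and compound 3 shows that an amine without phenyl already reaches the limit. Among the compounds with values here, no step bears directly on compound 2 against compound 4. The expectation is therefore no step beyond the scatter, a step that the limit leaves unreadable from compound 2 to compound 4, with compound 4 most likely again at the limit. The estimate for compound 4 in this assay is 20000 nM, between 7000 nM and 60000 nM.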

Compound 4, half-maximal inhibitory concentration: > 16000 nM
Compound 4: only a limit was reported; the forecaster's own chance of this, stated with the estimate: 70%; the middle value lies beyond the limit too.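

Compound 2 and compound 4 both stop at a limit in this assay, so no step can be read between them: the limit of > 16000 nM in this assay, at which 3 of the 4 values shown sit.

The compounds shown leave open whether dipropylamino and azetidin-1-yl differ at all in this read-out.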